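This account rests on a few compounds, and the source may have more. Where it says the series, first, only, none or still open, it means among the compounds named here.

Measured compounds:
- Compound 1 `CC(C)CC1C(=O)N(C)c2cnc(Nc3ccc(S(N)(=O)=O)cc3)nc2N1C`: 77 nM
- Compound 2 `CN1C(=O)C(c2cccc(C(F)(F)F)c2)N(C)c2nc(Nc3ccc(S(N)(=O)=O)cc3)ncc21`: 2710 nM

In an assay on Sf9 cells for inhibition of serine/threonine-protein kinase 4 (Homo sapiens), read by luminescence and ADP-Glo, with a stated time of 1 h, in the presence of a further agent that is not named here (on this read-out higher numbers stand for weaker inhibition and lower numbers for stronger inhibition), compound 1 gives 77 nM and compound 2 gives 2710 nM. Compound 2 thus has the higher of the two numbers, with compound 1 standing a 35-fold higher number from compound 1 to compound 2 (1.55 log units; beyond the scatter) away. Compound 3 `CN1C(=O)C(c2ccccc2Br)N(C)c2nc(Nc3ccc(S(N)(=O)=O)cc3)ncc21` has not yet been measured. It differs from compound 2 by 2-bromophenyl in place of 3-(trifluoromethyl)phenyl on a saturated ring carbon. Among the compounds with values here, the only measured step, a 35-fold higher number from compound 1 to compound 2 (1.55 log units; beyond the scatter), compares an aryl group with isobutyl at this saturated ring carbon and says nothing about one aryl group against another; no step compares two aryl groups here. Compound 3 is therefore expected to stay near compound 2, with a step of a 1.5-fold lower number from compound 2 to compound 3 (0.18 log units; within the scatter) that may not pass the scatter. The value of compound 3 in this assay is estimated at 1800 nM, within 450 nM to 7000 nM.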

Compound 3, half-maximal inhibitory concentration: 57 nM
For compound 3 the middle estimate is 32-fold (1.50 log units) above the measured one; measured number outside the range, below it.
By their numbers in this assay, from the lowest: compounds 3 and 1 (each within the scatter of the next); then compound 2.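

Within the data shown here, at this saturated ring carbon, the earlier compounds compared only an aryl group with isobutyl, whereas here the choice between two aryl groups is itself a large change, with a 48-fold lower number from compound 2 to compound 3 (1.68 log units; beyond the scatter) in this assay. An aryl group at this carbon therefore does not by itself bring the high number of compound 2, and the printed step a 1.4-fold lower number from compound 1 to compound 3 (0.13 log units; within the scatter) lies within the scatter, so 2-bromophenyl and isobutyl cannot be told apart here. The data offer no evidence on what lies behind the gap between the two aryl groups.

The change from compound 2 to compound 3 alters both the substituent and its place on the phenyl ring, and the compounds shown do not separate the two. A 3-bromophenyl, a 2-(trifluoromethyl)phenyl or an unsubstituted phenyl group would be needed to tell which of them counts.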